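The source may report more compounds than this note shows. Statements on the series, on what has been measured and on what is new or still open speak of the compounds shown alone.

Measured in a functional assay on L1210 cells (Mus musculus) for cytotoxicity; a lower number here means a stronger inhibitor, a higher number a weaker inhibitor:
- Compound 1 `COC(=O)[C@@H]1Cc2ccc(OC)c(c2)Oc2ccc(cc2)C[C@H](N(C)C(=O)OCc2ccccc2)C(=O)N1C`: 0.04 ug/mL
- Compound 2 `COC(=O)[C@@H]1Cc2ccc(OC)c(c2)Oc2ccc(cc2)C[C@H](N(C)C(=O)OCc2ccccc2)C(=O)N1`: 0.05 ug/mL

Compound 1 and compound 2 lie within the usual scatter of each other, so neither ranks ahead. Compound 3 `COC(=O)[C@@H]1Cc2ccc(OC)c(c2)Oc2ccc(cc2)C[C@H](N(C)C(=O)OC(C)(C)C)C(=O)N1C` has not been measured. It carries tert-butyl in place of benzyl on an oxygen next to a carbonyl group. Within the data shown here, the only measured step, a 1.3-fold higher number from compound 1 to compound 2 (0.10 log units; within the scatter), swaps methyl for hydrogen on an amide-type nitrogen in a ring, so it does not test this change. With no evidence for a shift, the expected step is a 1.5-fold higher number from compound 1 to compound 3 (0.18 log units; within the scatter), none beyond the scatter. For compound 3 the estimated value is 0.06 ug/mL, with an expected range of 0.015 ug/mL to 0.25 ug/mL.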

Compound 3, half-maximal inhibitory concentration: 0.03 ug/mL
The estimate for compound 3 lay 2.0-fold (0.30 log units) above the measured number; measured number inside the range.
By their numbers in this assay, from the lowest: compounds 3, 1 and 2 (each within the scatter of the next).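

Putting tert-butyl in place of benzyl on an oxygen next to a carbonyl group gives a 1.3-fold lower number from compound 1 to compound 3 (0.12 log units; within the scatter) in this assay. This position therefore tolerates losing the six-membered aromatic ring of the benzyl group: 4 heavy atoms serve here as well as 7, with no shift beyond the scatter. Nothing available explains this result. Still open, from the compounds shown here alone, is whether a much smaller methyl on this oxygen would hold the number, or whether a free amine, with the whole tert-butoxycarbonyl group removed, would do so.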